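Dropping the Chloro Substituent from Compound 1

The source may report more compounds than this note shows. Statements on the series, on what has been measured and on what is new or still open speak of the compounds shown alone.

Measured compounds:
Compound 1 `Cc1c(OCCCCOc2ccc(C(=O)O)cc2Cl)ccc(C(=O)CC2CCCC2)c1O` — 237 nM
Compound 2 `Cc1c(OCCCCOc2ccc(C(=O)CC(C)(C)C)c(O)c2C)cccc1C(=O)O` — 136 nM
Compound 3 `CCC(=O)c1ccc(OCCCCOc2ccc(F)c(C(=O)O)c2)c(C)c1O` — 124 nM

These three compounds were tested in an assay on HEK293 cells for positive allosteric modulation of metabotropic glutamate receptor 2 (Rattus norvegicus), read by thallium flux, with a stated time of 2.5 min; on this read-out higher numbers stand for an effect only at larger amounts of compound and lower numbers for an effect already at smaller amounts. Compound 1 gives 237 nM, the highest of the three numbers, yet its separation from compound 2 and from compound 3 lies within the usual scatter of the method, so no order among them can be claimed. Compound 2 gives 136 nM and compound 3 gives 124 nM.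

The next compound, compound 4 `Cc1c(OCCCCOc2ccc(C(=O)O)cc2)ccc(C(=O)CC2CCCC2)c1O`, has not yet been measured. It differs from compound 1 in one place: hydrogen in place of chloro on an aromatic carbon. The change sits ortho to a large group and meta to a carboxy group on the six-membered aromatic ring of carbon only.

Within the data shown here, no step between two measured compounds isolates this change, so the expectation rests on compound 1 alone. A step of the size a 1.3-fold higher number from compound 1 to compound 4 (0.10 log units; within the scatter) is expected, which would keep compound 4 within the scatter of compound 1. Compound 4 is therefore estimated at 300 nM in this assay, with a range from 120 nM to 750 nM.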

Compound 4, half-maximal effective concentration: 824 nM
Compound 4: the middle estimate sits 2.7-fold (0.44 log units) below what was measured, outside the stated range (above it).
By their numbers in this assay, from the lowest: compounds 3, 2 and 1 (each within the scatter of the next); then compound 4.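

In this assay, the change from 4-carboxy-2-chlorophenyl to 4-carboxyphenyl gives a 3.5-fold higher number from compound 1 to compound 4 (0.54 log units; beyond the scatter), so this aromatic carbon, ortho to a large group and meta to a carboxy group, is not indifferent to what it carries. Hydrogen there goes with an effect only at larger amounts of compound than chloro does, at least on the core of compound 1. The earlier compounds differ from one another in more than one place and could not show this, and nothing measured here says what lies behind the step.

From the compounds shown here alone, whether a bromo, methoxy or nitrile group at the same carbon would match chloro or fall nearer hydrogen remains open. So does whether the step would recur with a different ketone side chain.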